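The compounds below may be only part of what the source reports. "The series", "measured", "known", "first", "only" and "open" are said of these compounds alone.

Within the data shown here, compound 2, with the structure `COc1cc(-c2cc(/C=C/C(=O)c3ccc(N)cc3)[nH]n2)cc(OC)c1OC`, is the stronger of the two compounds measured so far. In a functional assay on BT-549 cells (Homo sapiens) for cytotoxicity, read by sulforhodamine B assay, with a stated time of 48 h, tested at 100 uM (a higher number here means a weaker effect of the compound at the concentration tested, a lower number a stronger effect), compound 2 gives -97%. Compound 1, with the structure `COc1ccc(-c2cc(/C=C/C(=O)c3ccc(N)cc3)[nH]n2)cc1`, carries a single methoxy group on its left-hand ring where compound 2 carries three; in this assay compound 1 gives -61%, a number that lies well beyond the usual scatter from compound 2.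

Compound 3, with the structure `COc1cc(-c2cc(/C=C/C(=O)c3ccc(Cl)c(Cl)c3)[nH]n2)cc(OC)c1OC`, has not yet been measured. It keeps the core of compound 2 and differs at the far end of the molecule: 3,4-dichlorophenyl in place of 4-aminophenyl on a carbonyl carbon. Among the measured compounds shown here, no measured pair shows this exact change, so its effect is uncertain. Compound 3 is expected to remain strongly active, with a modest step of a number 17 percentage points higher from compound 2 to compound 3 (beyond the scatter) towards a weaker effect. The estimate for compound 3 is -80%, within a range of -100% to -45%.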

Compound 3, a percentage reported as activity, at one concentration (the size of the read-out at that concentration, not a potency): -53%
For compound 3 the middle estimate is 27 percentage points below the measured one; the range from low to high includes it.
By their numbers in this assay, from the lowest: compound 2; then compounds 1 and 3 (each within the scatter of the next).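

In this assay putting 3,4-dichlorophenyl in place of 4-aminophenyl on a carbonyl carbon gives a number 44 percentage points higher from compound 2 to compound 3 (beyond the scatter) and so a large loss of effect. Among these compounds, this is the first sign that the group at this far end of the molecule counts, and not only the methoxy groups on the left-hand ring. With the rest of compound 2 kept, 4-aminophenyl is the better of the two groups shown here, and no measured evidence on why is at hand.

The change removes the amine and adds two chlorines at once, so the compounds shown leave open which of these accounts for the step. A plain phenyl or a 4-chlorophenyl on the same carbonyl carbon would help to tell the two apart.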